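This account rests on a few compounds, and the source may have more. Where it says the series, first, only, none or still open, it means among the compounds named here.

Compound 1 `Cn1nc(C(C)(C)C)cc1NC(=O)Nc1cc(C(F)(F)F)cc(C(F)(F)F)c1` gives 2.4 degrees C in an assay on isolated protein for inhibition of STE20-like serine/threonine-protein kinase (Homo sapiens), read by thermal shift assay, tested at 10 uM; on this read-out lower numbers stand for weaker stabilisation of the target and higher numbers for stronger stabilisation of the target against heat. Compound 2 `Cn1nc(-c2ccccc2)cc1NC(=O)Nc1cc(C(F)(F)F)cc(C(F)(F)F)c1` gives 1.9 degrees C in this assay. Compound 3 `Cn1nc(C(C)(C)C)cc1NC(=O)Nc1cc(F)cc(F)c1` gives 1.2 degrees C in this assay.

Compound 1 and compound 2 differ in one place: phenyl in place of tert-butyl on an aromatic carbon. This step gives a number 0.50 degrees C lower from compound 1 to compound 2 (within the scatter). Compound 3 shares the tert-butyl of compound 1 but the two cores differ in more than one place; that difference is not broken down here. Compound 4 `Cn1nc(-c2ccccc2)cc1NC(=O)Nc1cc(F)cc(F)c1` is not yet measured; it arises from compound 3 by the same change, (phenyl in place of tert-butyl on an aromatic carbon). Because the measured step of a number 0.50 degrees C lower from compound 1 to compound 2 (within the scatter) lies within the usual scatter, the estimated step for compound 4 is similar and small, a number 0.50 degrees C lower from compound 3 to compound 4 (within the scatter). Compound 4 is therefore expected to give about 0.7 degrees C in this assay, within a range from -0.4 degrees C to 1.8 degrees C.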

Compound 4, shift of the target's melting temperature: 0.8 degrees C
Estimate against measurement, compound 4: 0.10 degrees C below; low and high end bracket the measured number.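

Phenyl in place of tert-butyl gives a number 0.40 degrees C lower from compound 3 to compound 4 (within the scatter) in this assay, and this step agrees with the earlier one: the same change on two cores in this assay, a number 0.50 degrees C lower (within the scatter) from compound 1 to compound 2 and a number 0.40 degrees C lower (within the scatter) from compound 3 to compound 4, 0.10 degrees C apart, within the scatter of two such steps. On these two cores, then, the change carries over with much the same small size. Both steps lie within the scatter, however, so the pair does not show that the change moves the read-out at all, and two cores cannot vouch for the rest of the series.

The compounds shown leave open whether an amine, a carboxylic acid or a longer chain in place of tert-butyl would shift the number beyond the scatter. They also leave open how the phenyl change behaves on any third core.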